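The source may report more compounds than this note shows. Statements on the series, on what has been measured and on what is new or still open speak of the compounds shown alone.

In a functional assay on WiDr cells (Homo sapiens) for antiproliferative activity, read by sulforhodamine B assay, with a stated time of 48 h (on this read-out lower numbers stand for stronger inhibition of growth and higher numbers for weaker inhibition of growth), compound 1 (`CC(C)(C)[Si](C)(C)O[C@@H]1CCCO[C@@H]1/C=C/C(=O)OCc1ccccc1`) gives 90000 nM, a weak result on this scale. For compound 2 (`CC(C)(C)[Si](C)(C)O[C@@H]1CCCO[C@@H]1/C=C\CO`), the assay reports only a limit, > 100000 nM, and not a number. Its exact place is therefore unknown, and the evidence so far can be summed up as the limit of > 100000 nM in this assay, at which 1 of the 2 values shown sits.

Compound 3 (`CC(C)(C)[Si](C)(C)O[C@@H]1CCCO[C@@H]1/C=C/C(=O)O`) keeps the shared core but has 2-carboxyethenyl in place of 3-hydroxyprop-1-en-1-yl on a saturated ring carbon. Among the compounds with values here, no measured pair in this small set isolates that change, so the data offer no direct guide to its size or direction. Within the data shown here, the only firm number, 90000 nM for compound 1, shows weak growth inhibition, so compound 3 is expected to stay weak as well. In this assay, no step beyond the usual scatter is expected, and neither direction is favoured. The estimated change is an at least 1.1-fold lower number from compound 2 to compound 3 (0.04 log units; that floor lies within the scatter). Compound 3 is expected to give about 90000 nM, with an estimated range from 40000 nM to 200000 nM, and the assay may again report only a limit.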

Compound 3, concentration for 50% growth inhibition: > 100000 nM
Compound 3 ended at the assay's limit; the forecaster's own chance of this, stated with the estimate: 60%; at least 1.1-fold (0.04 log units) between middle value and limit.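

Compound 3 gives > 100000 nM in this assay, which is a limit of the assay and not a number. Within the data shown here, its comparison with compound 1 adds the first readable step at this position: with hydrogen in place of benzyl on an oxygen next to a carbonyl group, the result is an at least 1.1-fold higher number from compound 1 to compound 3 (0.04 log units; that floor lies within the scatter), so only a minimum is known, and even that minimum does not separate the two compounds beyond ordinary assay variation. Compound 2 and compound 3 both stand at limits, so the step between them cannot be read, and swapping 3-hydroxyprop-1-en-1-yl for 2-carboxyethenyl has no measurable size or direction; what the position has yielded so far is best summed up this way: the limit of > 100000 nM in this assay, at which 2 of the 3 values shown sit.

From the compounds shown here alone, the true values of compound 2 and compound 3 remain unknown, so it is still open how far either lies from compound 1 or from the other. Going by these compounds, it is also open whether an amine, an amide or a longer chain at this position would bring the result into the measurable range of the assay.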